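The compounds below may be only part of what the source reports. "The series", "measured", "known", "first", "only" and "open" are said of these compounds alone.

Measured compounds in a functional assay on MCF7 cells (Homo sapiens) for inhibition, read by MTT assay, with a stated time of 72 h; on this read-out higher numbers stand for weaker inhibition and lower numbers for stronger inhibition:
Compound 1, `COc1cc2c(Oc3ccc(NC(=O)c4nn(-c5ccccc5C)cc(C)c4=O)cc3F)ccnc2cc1OCCCC(=O)NO`, gives 2600 nM.
Compound 2, `COc1cc2c(Oc3ccc(NC(=O)c4nn(-c5ccccc5C)cc(C)c4=O)cc3)ccnc2cc1OCCCCCCC(=O)NO`, gives 1830 nM.
Compound 3, `COc1cc2c(Oc3ccc(NC(=O)c4nn(-c5ccccc5)cc(C)c4=O)cc3F)ccnc2cc1OCCCC(=O)NO`, gives 1900 nM.

The three values lie within the usual scatter of one another, so no order among them is claimed. Compound 3 differs from compound 1 by one change, (hydrogen in place of methyl on an aromatic carbon), and that change gave a 1.4-fold lower number from compound 1 to compound 3 (0.14 log units; within the scatter). Compound 4, `COc1cc2c(Oc3ccc(NC(=O)c4nn(-c5ccccc5)cc(C)c4=O)cc3)ccnc2cc1OCCCCCCC(=O)NO`, has not been measured in this assay; it differs from compound 2 by the same change, (hydrogen in place of methyl on an aromatic carbon), at the same kind of place. The difference between the cores of compound 2 and compound 1 is not broken down here.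

Because the earlier step read a 1.4-fold lower number from compound 1 to compound 3 (0.14 log units; within the scatter), a step of about the same size is expected here, a 1.3-fold lower number from compound 2 to compound 4 (0.12 log units; within the scatter). Compound 4 is therefore estimated to give 1400 nM in this assay, most likely between 700 nM and 3000 nM.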

Compound 4, half-maximal inhibitory concentration: 1610 nM
The estimate for compound 4 lay 1.2-fold (0.06 log units) below the measured number; measured number inside the range.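

In this assay, the change from 2-methylphenyl to phenyl on the core of compound 2 gave a 1.1-fold lower number from compound 2 to compound 4 (0.06 log units; within the scatter), a step within the scatter, as on the core of compound 1. The two readings of the change agree: the same change on two cores in this assay, a 1.4-fold lower number (0.14 log units; within the scatter) from compound 1 to compound 3 and a 1.1-fold lower number (0.06 log units; within the scatter) from compound 2 to compound 4, 1.2-fold (0.08 log units) apart, within the scatter of two such steps. This shows that, on these two cores, the change carried over with no step beyond the scatter, but it does not show how the change would read on any other core, and the difference between the two cores remains unresolved.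

The compounds shown leave open whether a larger group at the same place, such as trifluoromethyl or a chlorine atom, would read differently. They also leave open whether an amine or a carboxylic acid at the chain end would change the number.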